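The source may hold more compounds than are shown below. What is called first, only, known or untested is meant among the compounds shown, and "the series" means these compounds.

In an assay on CHO-K1 cells for displacement of a labelled ligand from adenosine receptor A1 (Homo sapiens), tested at 10 uM (a higher number here means more inhibition at the concentration tested (going by the name of the read-out), a lower number less inhibition), compound 1 `Nc1scc(-c2cccc(C(F)(F)F)c2)c1C(=O)c1ccccc1` gives 61.1%. Among the compounds with values here, compound 2 `CC(=O)c1ccc(-c2sc(N)c(C(=O)c3ccccc3)c2-c2cccc(C(F)(F)F)c2)cc1`, which carries 4-acetylphenyl in place of hydrogen on an aromatic carbon, gives 25.6% in this assay; that is the lower of the two numbers measured so far, and the step of a number 35.5 percentage points lower from compound 1 to compound 2 (beyond the scatter) was large. Compound 3 `CCOC(=O)c1c(N)sc(-c2ccc(C(C)=O)cc2)c1-c1cccc(C(F)(F)F)c1` keeps the shared core of compound 2 together with its 4-acetylphenyl and differs from it at one place only: ethoxy in place of phenyl on a carbonyl carbon Cut one bond further out, the difference reads benzoyl to ethoxycarbonyl. Within the data shown here, no measured step touches this part of the molecule: the single step available changed a group on an aromatic carbon, not on the carbonyl carbon, so it gives no guidance on size or direction here. The cautious expectation is therefore a step of no clear size beyond the scatter, a number 0.6 percentage points lower from compound 2 to compound 3 (within the scatter), with wide uncertainty. On that basis compound 3 is estimated at 25%, within 5% to 50%.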

Compound 3, a percentage reported as inhibition, at one concentration (the size of the read-out at that concentration, not a potency): 64.6%
Beside the measured number, compound 3's estimate is 39.6 percentage points below it, and the stated range ends below it.
By their numbers in this assay, from the lowest: compound 2; then compounds 1 and 3 (each within the scatter of the next).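

The carbonyl carbon is a position where the choice of group strongly affects the result: in this assay, ethoxy in place of phenyl gives a number 39 percentage points higher from compound 2 to compound 3 (beyond the scatter). This large step occurs with 4-acetylphenyl kept in place, so the loss seen when that group entered is not a fixed outcome for every compound carrying it. The change removes a six-membered aromatic ring and adds a hydrogen-bond acceptor, and a single step cannot show which of these differences matters. No measurement shown here explains the rise.

As far as these compounds go, it remains open whether methoxy, a longer butoxy chain or an amine on this carbonyl carbon would give a similarly high number. Also open, from the compounds shown here alone, is whether ethoxy in place of phenyl would give a similar step in a compound without 4-acetylphenyl.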